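A Fluorinated Phenyl Replaces a Pyridinylmethyl Arm

This account rests on a few compounds, and the source may have more. Where it says the series, first, only, none or still open, it means among the compounds named here.

Three compounds share one core and differ only in the group attached to an amine nitrogen in a six-membered non-aromatic ring with two nitrogens. Compound 3 `Nc1ccccc1NC(=O)c1ccc(CSC(=S)N2CCN(Cc3cccnc3)CC2)cc1` carries a (pyridin-3-yl)methyl group there; in a functional assay on HeLa cells (Homo sapiens) for antiproliferative activity, read by CCK-8 assay, with a stated time of 72 h, tested at 8 uM (a higher number here means a stronger effect of the compound at the concentration tested, a lower number a weaker effect), compound 3 gives 78%. That is the highest of the three numbers, yet both neighbours sit within the scatter of it: compound 1 `Nc1ccccc1NC(=O)c1ccc(CSC(=S)N2CCN(c3ccccc3)CC2)cc1`, with a phenyl group, gives 73.1%, and compound 2 `N#Cc1ccc(N2CCN(C(=S)SCc3ccc(C(=O)Nc4ccccc4N)cc3)CC2)cc1`, with a 4-cyanophenyl group, gives 70.6%. The steps between them are small: a number 4.9 percentage points higher from compound 1 to compound 3 (within the scatter), a number 7.4 percentage points higher from compound 2 to compound 3 (within the scatter) and a number 2.5 percentage points lower from compound 1 to compound 2 (within the scatter).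

Compound 4 `Nc1ccccc1NC(=O)c1ccc(CSC(=S)N2CCN(c3ccccc3F)CC2)cc1` is not yet measured. It differs from compound 3 in one place: 2-fluorophenyl in place of (pyridin-3-yl)methyl on an amine nitrogen in a ring. Among the measured compounds shown here, two measured steps bear on this: the step from a phenyl group to the (pyridin-3-yl)methyl group, a number 4.9 percentage points higher from compound 1 to compound 3 (within the scatter), and the step that adds a cyano group to a phenyl group, a number 2.5 percentage points lower from compound 1 to compound 2 (within the scatter). Both stayed within the scatter, so going back to a phenyl group that now carries a fluorine is expected to move the number little, most likely a number 5 percentage points lower from compound 3 to compound 4 (within the scatter). Compound 4 is therefore estimated to give 73%, expected to lie between 62% and 82%.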

Compound 4, a percentage reported as inhibition, at one concentration (the size of the read-out at that concentration, not a potency): 59.2%
Compound 4: the middle estimate sits 13.8 percentage points above what was measured; measured number outside the range, below it.
By their numbers in this assay, from the lowest: compound 4; then compounds 2, 1 and 3 (each within the scatter of the next).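

In this assay, among the compounds shown here, the swaps at this ring nitrogen had so far stayed within the scatter, but the single fluorine brings the first clear change: a number 13.9 percentage points lower from compound 1 to compound 4 (beyond the scatter). This is the most direct reading of the new result, since only a hydrogen on an aromatic carbon is replaced, and the other two comparisons point the same way, with a number 11.4 percentage points lower from compound 2 to compound 4 (beyond the scatter) and a number 18.8 percentage points lower from compound 3 to compound 4 (beyond the scatter), so a substituted phenyl group at this position cannot be assumed to behave like the plain phenyl group, even though the 4-cyanophenyl group of compound 2 stayed within the scatter of compound 1. No measurement other than these percentages bears on why the number falls.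

The compounds shown leave open whether the fall belongs to fluorine itself or would also follow from a chlorine or a methoxy group in the same place on the phenyl group. They also leave open whether the weaker effect would be seen at other concentrations, as each number is the size of the effect at a single concentration in one cell line.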